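A Small Chain Extension Tried Twice

The source may hold more compounds than are shown below. What is called first, only, known or untested is meant among the compounds shown, and "the series" means these compounds.

Compound 1 `COC[C@H]1O[C@@H](n2c(Cl)nc3cc(Cl)c(Cl)cc32)[C@H](OC(C)=O)[C@@H]1OC(C)=O`: 80000 nM
Compound 2 `CCOC[C@H]1O[C@@H](n2c(Cl)nc3cc(Cl)c(Cl)cc32)[C@H](OC(C)=O)[C@@H]1OC(C)=O`: 60000 nM
Compound 3 `COC[C@H]1OC(n2c(Cl)nc3cc(Cl)c(Cl)cc32)[C@H](O)[C@@H]1O`: 90000 nM

All three numbers come from a functional assay on KB cells (Homo sapiens) for inhibition; a lower number here means a stronger inhibitor, a higher number a weaker inhibitor. Compound 4 `CCOC[C@H]1OC(n2c(Cl)nc3cc(Cl)c(Cl)cc32)[C@H](O)[C@@H]1O` has not been measured yet. The difference between the core of compound 1 and the core of compound 3 is not broken down here. Compound 4 arises from compound 3 by one change: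
methyl in place of hydrogen on a saturated chain carbon bound to an oxygen on a saturated carbon
The same change, at the same place, was made from compound 1 to compound 2:
methyl in place of hydrogen on a saturated chain carbon bound to an oxygen on a saturated carbon
That earlier step gave a 1.3-fold lower number from compound 1 to compound 2 (0.12 log units; within the scatter). Because a 1.3-fold lower number from compound 1 to compound 2 (0.12 log units; within the scatter) is small and the change is the same, the step to compound 4 is expected to be similar, a 1.3-fold lower number from compound 3 to compound 4 (0.11 log units; within the scatter). Compound 4 is therefore estimated at 70000 nM, with a likely range from 30000 nM to 160000 nM.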

Compound 4, half-maximal inhibitory concentration: 80000 nM
Compound 4: the middle estimate sits 1.1-fold (0.06 log units) below what was measured, and the stated range covers the measured number.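

In this assay, replacing methoxymethyl with ethoxymethyl gave a 1.1-fold lower number from compound 3 to compound 4 (0.05 log units; within the scatter), a step that lies within the usual scatter of the measurement. Set beside the earlier step, the change reads alike on both cores: the same change on two cores in this assay, a 1.3-fold lower number (0.12 log units; within the scatter) from compound 1 to compound 2 and a 1.1-fold lower number (0.05 log units; within the scatter) from compound 3 to compound 4, 1.2-fold (0.07 log units) apart, within the scatter of two such steps. This shows that the change left the number essentially unmoved on these two cores, but with neither step beyond the scatter, it does not show a real effect carried from one core to the other, and it says nothing about any further core.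

The compounds shown leave open whether a longer chain, an amine or a carboxylic acid in place of the ethyl would move the number beyond the scatter.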